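Third methyl on the aromatic ring of compound 3

The compounds below may be only part of what the source reports. "The series", "measured", "known", "first", "only" and "open" are said of these compounds alone.

Compound 1 `CCCCOc1ccc(Nc2nc3nonc3nc2O)cc1` and compound 2 `Oc1nc2nonc2nc1Nc1ccc(S(F)(F)(F)(F)F)cc1` each carry one group on the six-membered aromatic ring of carbon only. In an assay on mitochondria from L6 cells (Rattus norvegicus) for activation, with a stated time of 90 min (a lower number here means that less compound is needed, a higher number that more compound is needed for the effect), compound 1 gives 3700 nM. In the same assay compound 2 gives 3900 nM. Within the data shown here, the only step between measured compounds, a 1.1-fold higher number from compound 1 to compound 2 (0.02 log units; within the scatter), is within the scatter. Compound 3 `Cc1cccc(C)c1Nc1nc2nonc2nc1O` carries two methyl groups on that ring. In this assay compound 3 reaches only > 100000 nM, which is a limit of the assay and not a number (the limit of > 100000 nM in this assay, at which 1 of the 3 values shown sits). Among the measured compounds shown here, compound 3 is thus the one compound of the three whose value is a limit rather than a measured number.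

Compound 4 `Cc1cc(C)c(Nc2nc3nonc3nc2O)c(C)c1` differs from compound 3 by methyl in place of hydrogen on an aromatic carbon. For the measured compounds named here, no measured step concerns a methyl entering in place of hydrogen; the step from compound 1 to compound 2 exchanges other groups and was within the scatter, so it gives no direction for the present change. The starting point being a limit, the expectation for compound 4 rests on that limit alone. Compound 4 is expected to stay at the limit in this assay, with an estimated 100000 nM between 30000 nM and 300000 nM. The implied step a number no higher from compound 3 to compound 4 (the limit leaves the size open) is expected to be none beyond the scatter.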

Compound 4, half-maximal effective concentration: 113000 nM
For compound 4 the middle estimate is 1.1-fold (0.05 log units) below the measured one; the measured number falls inside the stated range.
By their numbers in this assay, from the lowest: compounds 1 and 2 (each within the scatter of the next); then compound 4.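

No step from compound 3 to compound 4 can be read, because compound 3 gives only a limit of the assay and not a number: the limit of > 100000 nM in this assay, at which 1 of the 4 values shown sits.

The compounds shown leave open what methyl in place of hydrogen on an aromatic carbon does in this assay when the starting compound has a measured number.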